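Swapping the Aryl Group on a Series at the Limit

The compounds below may be only part of what the source reports. "The series", "measured", "known", "first", "only" and "open" are said of these compounds alone.

Compound 1, `C/C(=C\CC/C(C)=C/CC[C@@H]1[C@@]2(C)CCC(=O)C(C)(C)[C@H]2CC[C@@]1(C)O)CC/C=C(\C)C(=O)OCc1cn(-c2ccc([N+](=O)[O-])cc2)nn1`, gives > 150000 nM in a functional assay on DU-145 cells (Homo sapiens) for antiproliferative activity, read by MTT assay, with a stated time of 48 h; a lower number here means a stronger inhibitor, a higher number a weaker inhibitor; this is a limit, not a measured number.
Compound 2, `COc1cccc(-n2cc(COC(=O)/C(C)=C/CC/C(C)=C/CC/C(C)=C/CC[C@@H]3[C@@]4(C)CCC(=O)C(C)(C)[C@H]4CC[C@@]3(C)O)nn2)c1`, gives > 150000 nM in this assay; this too is a limit.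
Compound 3, `C/C(=C\CC/C(C)=C/CC[C@@H]1[C@@]2(C)CCC(=O)C(C)(C)[C@H]2CC[C@@]1(C)O)CC/C=C(\C)C(=O)OCc1cn(-c2ccc(C(C)(C)C)cc2)nn1`, gives > 150000 nM in this assay; again only a limit.

Compound 3 therefore stands on no number at all: its value is a limit, and the two other values shown are limits as well, all sitting at the limit of > 150000 nM in this assay, at which 3 of the 3 values shown sit. Compound 4, `C/C(=C\CC/C(C)=C/CC[C@@H]1[C@@]2(C)CCC(=O)C(C)(C)[C@H]2CC[C@@]1(C)O)CC/C=C(\C)C(=O)OCc1cn(-c2cccc([N+](=O)[O-])c2)nn1`, has not yet been measured. It differs from compound 3 in one place: 3-nitrophenyl in place of 4-(tert-butyl)phenyl on an aromatic nitrogen.

Among the measured compounds shown here, three measured steps bear on this change, since they all exchange the group on the same aromatic nitrogen: a step that the two limits leave unreadable from compound 1 to compound 3, a step that the two limits leave unreadable from compound 2 to compound 3 and a step that the two limits leave unreadable from compound 1 to compound 2. None of them has a readable size. Every value involved is a limit. So no step can be expected in either direction beyond the scatter; the most likely outcome is another limit.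

Compound 4 is estimated at 150000 nM, with a range from 100000 nM to 300000 nM. The expected step is a number no higher from compound 3 to compound 4 (the limit leaves the size open).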

Compound 4, half-maximal inhibitory concentration: > 150000 nM
Compound 4: a limit, no number; the forecaster's own chance of this, stated with the estimate: 80%; the middle value sits exactly at the limit.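

Compound 4 gives > 150000 nM in this assay, which is again a limit. The steps to compound 4 from compound 1, compound 2 and compound 3 therefore cannot be read, and all the values stand together: the limit of > 150000 nM in this assay, at which 4 of the 4 values shown sit. The compounds shown leave open how these aryl groups rank against one another, and whether any of them changes the activity at all.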